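From pyridin-2-yl to 2,3-dichlorophenyl on the ring nitrogen

A few compounds are considered here, and "the series" means these few. Any claim that something is new, unique, unknown or untested is made for them only; others in the source may bear on it.

In a functional assay on DU-145 cells (Homo sapiens) for cytotoxicity, read by sulforhodamine B assay, with a stated time of 48 h (a lower number here means a stronger inhibitor of growth, a higher number a weaker inhibitor of growth), compound 3 `N#Cc1ccc(Nc2nc(Oc3ccnc4ccccc34)nc(N3CCN(c4ccccn4)CC3)n2)cc1C(F)(F)F` gives > 100000 nM, which is a limit and not a number. Compound 1 `N#Cc1ccc(Nc2nc(Oc3ccnc4ccccc34)nc(N3CCN(c4ccccc4Cl)CC3)n2)cc1C(F)(F)F`, with 2-chlorophenyl in that place, gives > 100000 nM, also a limit. Compound 2 `N#Cc1ccc(Nc2nc(Oc3ccnc4ccccc34)nc(N3CCN(c4cccc(C(F)(F)F)c4)CC3)n2)cc1C(F)(F)F`, with 3-(trifluoromethyl)phenyl there, gives a true number, 74100 nM. Compound 4 `N#Cc1ccc(Nc2nc(Oc3ccnc4ccccc34)nc(N3CCN(c4cccc(Cl)c4Cl)CC3)n2)cc1C(F)(F)F` has 2,3-dichlorophenyl in place of pyridin-2-yl on an amine nitrogen in a ring. The measured steps that bear on this change are an at least 1.3-fold higher number from compound 2 to compound 3 (0.13 log units; that floor lies within the scatter) and an at least 1.3-fold lower number from compound 1 to compound 2 (0.13 log units; that floor lies within the scatter), while a step that the two limits leave unreadable from compound 1 to compound 3 adds no readable size. No step beyond the scatter is therefore expected in this assay. The expected step is an at least 1.1-fold lower number from compound 3 to compound 4 (0.04 log units; that floor lies within the scatter). For compound 4 the estimated value is 90000 nM, with an expected range from 45000 nM to 180000 nM.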

Compound 4, concentration for total growth inhibition: > 100000 nM
Compound 4: no number, only a limit (the forecaster's own chance of this, stated with the estimate: 50%); middle value at least 1.1-fold (0.04 log units) away from the limit.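

In this assay, among the compounds shown here, the added chloro on an aromatic carbon that separates compound 4 from compound 1 brings no true number, so 2,3-dichlorophenyl joins 2-chlorophenyl and pyridin-2-yl, and compound 2 remains the only compound with one. Against compound 2, the change gives an at least 1.3-fold higher number from compound 2 to compound 4 (0.13 log units; that floor lies within the scatter). The steps from compound 1 and compound 3 to compound 4 cannot be read: the limit of > 100000 nM in this assay, at which 3 of the 4 values shown sit.

Going by these compounds, how far these three groups differ from one another therefore stays open. So does how a carboxylic acid or a longer chain on this ring nitrogen would read in this assay.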